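Exchanging a hydroxypiperidine for a dimethylmorpholine

A few compounds are considered here, and "the series" means these few. Any claim that something is new, unique, unknown or untested is made for them only; others in the source may bear on it.

Three compounds have numbers in a physicochemical assay for lipophilicity, at pH 7.4; a higher number here means a more lipophilic compound, a lower number a more polar compound. Within the data shown here, compound 1 `O=C(Nc1cccc(Cl)c1)c1cc(C(F)(F)F)ccc1OCc1ccc(F)cc1` gives 8.7, and compound 3 `O=C(Nc1cccc(Cl)c1)c1cc(C(F)(F)F)ccc1OCc1ccccc1` gives 8.8; the one step between them, a number 0.10 log units higher from compound 1 to compound 3 (within the scatter), is hydrogen in place of fluoro on an aromatic carbon. Compound 2 `O=C(Nc1ccnnc1)c1cc(N2CCC(O)CC2)ccc1OCc1ccccc1` gives 3.2 and stands lowest of the three, far from both others beyond the scatter.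

Compound 4 `C[C@@H]1CN(c2ccc(OCc3ccccc3)c(C(=O)Nc3ccnnc3)c2)C[C@H](C)O1` has not been measured. It differs from compound 2 as follows: 2,6-dimethylmorpholin-4-yl in place of 4-hydroxypiperidin-1-yl on an aromatic carbon

Among the measured compounds shown here, no measured step touches this part of the structure. For the measured compounds named here, the only step that is known, from compound 1 to compound 3, is within the scatter and changes a single substituent on a different ring, so it says nothing about what happens when the 4-hydroxypiperidin-1-yl group leaves and the 2,6-dimethylmorpholin-4-yl group enters. The expectation therefore rests on the change itself, as counted above: the group that enters is slightly larger and carries no hydrogen-bond donor, and the writer expects the number to move upward, beyond the scatter, by a number 1.00 log units higher from compound 2 to compound 4 (beyond the scatter). For compound 4 in this assay the estimate is 4.2, with a range from 3.5 to 5.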

Compound 4, distribution coefficient: 5.4
Compound 4: middle estimate off by 1.20 log units, on the low side; measured number above the stated range.
By their numbers in this assay, from the lowest: compound 2; then compound 4; then compounds 1 and 3 (each within the scatter of the next).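

Among these compounds, the exchange of 4-hydroxypiperidin-1-yl for 2,6-dimethylmorpholin-4-yl gives the first measured step at this position, on the aromatic carbon meta to the (pyridazin-4-yl)carbamoyl group and para to the benzyloxy group: in this assay the number moves by a number 2.20 log units higher from compound 2 to compound 4 (beyond the scatter) for this single exchange. Among the compounds shown here, the read-out at this position is therefore far from indifferent to the group attached there, whereas the one earlier step, on a different ring, stayed within the scatter. The exchange takes the count from 1 hydrogen-bond donor to 0 hydrogen-bond donors, leaves 2 hydrogen-bond acceptors on each side and adds a ring hetero atom and two methyl groups, but no measurement given here bears on why the number moved as it did.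

The compounds shown leave open how the step divides among the hydroxyl group, the ring oxygen and the two methyl groups, a question that plain morpholin-4-yl and piperidin-1-yl groups at the same position would address. They also leave open where a 4-aminopiperidin-1-yl group or the other stereoisomer of 2,6-dimethylmorpholin-4-yl would fall in this assay on this scale.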